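Cytotoxicity notes: from compound 1 to compound 4

A few compounds are considered here, and "the series" means these few. Any claim that something is new, unique, unknown or untested is made for them only; others in the source may bear on it.

Compound 1 `CS(=O)(=O)c1ccc(C(=O)N2CCC(C(=O)N3CCN(c4ccc(F)cc4)CC3)CC2)cc1[N+](=O)[O-]` is compared with two relatives in an ADME assay on HepG2 cells (Homo sapiens) for cytotoxicity, read by CellTiter-Glo and ATP content, with a stated time of 72 h; on this read-out higher numbers stand for an effect only at larger amounts of compound and lower numbers for an effect already at smaller amounts. In this assay compound 1 gives only a limit, > 27000 nM. Compound 2 `CS(=O)(=O)c1ccc(C(=O)NCCCC(=O)N2CCCCC2)cc1[N+](=O)[O-]` likewise gives a limit in this assay, > 27000 nM. Compound 3 `CS(=O)(=O)c1ccc(C(=O)NCC(=O)N2CCCCC2)cc1[N+](=O)[O-]` gives a number in this assay, 14000 nM. Among the compounds with values here, compound 1 therefore stands at the limit of > 27000 nM in this assay, at which 2 of the 3 values shown sit, and no step between measured compounds is available. Compound 4 `CS(=O)(=O)c1ccc(C(=O)N2CCC(C(=O)N3CCN(c4ccccc4)CC3)CC2)cc1[N+](=O)[O-]` differs from compound 1 by hydrogen in place of fluoro on an aromatic carbon. All three measured values sit at or within the scatter of the limit, so no step beyond the scatter is expected from this change. For compound 4 the estimate in this assay is 27000 nM (range 14000 nM to 54000 nM), a step of a number no higher from compound 1 to compound 4 (the limit leaves the size open) expected to stay within the scatter.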

Compound 4, half-maximal effective concentration: > 27000 nM
Compound 4: no number, only a limit (the forecaster's own chance of this, stated with the estimate: 75%); the middle value sits exactly at the limit.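

In this assay compound 1 and compound 4 each give only a limit, so no step can be read between them. Going by these compounds, whether the change from 4-fluorophenyl to phenyl shifts cytotoxicity at all remains open.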